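This account rests on a few compounds, and the source may have more. Where it says the series, first, only, none or still open, it means among the compounds named here.

Measured so far in a functional assay on KM12 cells (Homo sapiens) for antiproliferative activity; on this read-out lower numbers stand for stronger inhibition of growth and higher numbers for weaker inhibition of growth:
compound 1 `Oc1ccc(-c2nc3cc(F)ccc3s2)cc1O` gives 13000 nM;
compound 2 `COc1ccc(-c2nc3cc(F)ccc3s2)cc1O` gives 18400 nM;
compound 3 `COc1cc(-c2nc3cc(F)ccc3s2)cc(OC)c1OC` gives 13000 nM.

Compound 1 and compound 2 share one core, and the change from compound 2 to compound 1 is hydrogen in place of methyl on an oxygen on an aromatic ring. In this assay that change gave a 1.4-fold lower number from compound 2 to compound 1 (0.15 log units; within the scatter). Compound 3 carries a different core; how its core differs from that of compound 2 is not broken down here. Compound 4 `COc1cc(-c2nc3cc(F)ccc3s2)cc(O)c1OC` is not yet measured. It arises from compound 3 by hydrogen in place of methyl on an oxygen on an aromatic ring, the same kind of change as that from compound 2 to compound 1, at the same kind of place. For compound 4 in this assay a step of a 1.2-fold lower number from compound 3 to compound 4 (0.07 log units; within the scatter) is expected, resting only on the step from compound 2 to compound 1 because that step read a 1.4-fold lower number from compound 2 to compound 1 (0.15 log units; within the scatter). The value of compound 4 is therefore estimated at 11000 nM, within 5000 nM to 25000 nM.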

Compound 4, concentration for 50% growth inhibition: 47500 nM
Compound 4: the middle estimate sits 4.3-fold (0.64 log units) below what was measured, and the stated range ends below it.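

In this assay, swapping methyl for hydrogen on an oxygen on an aromatic ring did not read the same on the two cores: the same change on two cores in this assay, a 1.4-fold lower number (0.15 log units; within the scatter) from compound 2 to compound 1 and a 3.7-fold higher number (0.56 log units; beyond the scatter) from compound 3 to compound 4, 5.2-fold (0.71 log units) apart, beyond the scatter of two such steps On the core of compound 3, this methoxy to hydroxy change weakened growth inhibition, with a 3.7-fold higher number from compound 3 to compound 4 (0.56 log units; beyond the scatter), and adding a methoxy in place of hydrogen on an aromatic carbon also gave weaker inhibition, with a 2.6-fold higher number from compound 2 to compound 4 (0.41 log units; beyond the scatter). So a step measured on one core cannot simply be carried to the other here, but two pairs do not show why the cores differ or what a further core would do.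

From the compounds shown here alone, it remains open how an amine or a longer chain such as ethoxy would read in place of that hydroxy.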